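The source may hold more compounds than are shown below. What is called first, only, known or untested is meant among the compounds shown, and "the series" means these compounds.

The measured compounds are:
compound 1, `Cc1[nH]n(-c2nc3c(C)cccc3[nH]2)c(=O)c1C`; compound 2, `Cc1[nH]n(-c2nc3ccccc3[nH]2)c(=O)c1CC(=O)O`; compound 3, `Cc1[nH]n(-c2nc3ccccc3[nH]2)c(=O)c1Cc1ccccc1Cl`.

In an assay on isolated protein for inhibition of alpha-ketoglutarate-dependent dioxygenase alkB homolog 3 (Homo sapiens), read by polymerase chain reaction, with a stated time of 1 h (a lower number here means a stronger inhibitor, a higher number a weaker inhibitor), compound 2 gives 15000 nM. Compound 1 gives > 10000 nM, which is a limit of the assay and not a number. Compound 3 gives > 10000 nM, likewise a limit and not a number. So compound 3 stands only at a limit, namely (the limit of > 10000 nM in this assay, at which 2 of the 3 values shown sit), and nothing more exact is known about it. The step that the limit leaves unreadable from compound 2 to compound 3 cannot be read in size, since its end point is hidden by the limit of > 10000 nM in this assay, at which 2 of the 3 values shown sit.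

Compound 4, `Cc1[nH]n(-c2nc3ccccc3[nH]2)c(=O)c1Cc1ccc(Cl)cc1`, differs from compound 3 by 4-chlorophenyl in place of 2-chlorophenyl on a saturated chain carbon bound to an aromatic carbon. Within the data shown here, no measured step compares a 2-chlorophenyl with a 4-chlorophenyl, and the only step that reaches compound 3 is unreadable, so no direction of change beyond the scatter can be expected from the data. The step from compound 3 to compound 4 is therefore estimated as a step that the limit leaves unreadable from compound 3 to compound 4, essentially no change. Compound 4 is expected at 15000 nM, within a range from 4000 nM to 60000 nM, most likely again reported only as a limit.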

Compound 4, half-maximal inhibitory concentration: > 10000 nM
Compound 4 gave a limit, no number; the forecaster's own chance of this, stated with the estimate: 70%; the middle value does not contradict the limit.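

In this assay compound 4 gives > 10000 nM, a limit of the assay and not a number. Among these compounds, no step to compound 4, from compound 2 or from compound 3, can be read in size: the limit of > 10000 nM in this assay, at which 3 of the 4 values shown sit. On these data alone, whether the 2-chlorobenzyl of compound 3 and the 4-chlorobenzyl of compound 4 differ in strength, and how either compares with compound 2, stays open.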